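From bromo to iodo: expectation for compound 3

The compounds below may be only part of what the source reports. "The series", "measured", "known", "first", "only" and "open" are said of these compounds alone.

In a functional assay on HT-29 cells (Homo sapiens) for antiproliferative activity, read by sulforhodamine B assay, with a stated time of 48 h (a lower number here means a stronger inhibitor, a higher number a weaker inhibitor), compound 1 `CCN1CCN(c2ccc(S(=O)(=O)Oc3cccc(F)c3)cc2)C1=O` gives > 100000 nM, which is a limit of the assay. For the measured compounds named here, compound 2 `CCN1CCN(c2ccc(S(=O)(=O)Oc3cccc(Br)c3)cc2)C1=O` gives 3800 nM, the only actual number so far. Compound 3 `CCN1CCN(c2ccc(S(=O)(=O)Oc3cccc(I)c3)cc2)C1=O` carries iodo in place of bromo on an aromatic carbon, meta to a large group: iodo in place of bromo on an aromatic carbon. Going by the values given here, one measured step bears on this change, the bromo for fluoro exchange, an at least 26-fold lower number from compound 1 to compound 2 (1.42 log units; beyond the scatter), which is large and beyond the scatter. Among the compounds with values here, a smaller move in the same direction is expected, as the only precedent is that single step. The expected step is a 1.9-fold lower number from compound 2 to compound 3 (0.28 log units; within the scatter). Compound 3 is estimated at 2000 nM, with an expected range of 600 nM to 7000 nM.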

Compound 3, half-maximal inhibitory concentration: 3100 nM
Estimate against measurement, compound 3: 1.6-fold (0.19 log units) below, within the range that was stated.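

In this assay, iodo in place of bromo on an aromatic carbon, meta to a large group, gives a 1.2-fold lower number from compound 2 to compound 3 (0.09 log units; within the scatter), so bromo and iodo cannot be told apart here. Fluoro stands apart from both, with an at least 32-fold lower number from compound 1 to compound 3 (1.50 log units; beyond the scatter), which repeats what the bromo compound showed. The size of that step is only a bound, since compound 1 sits at a limit of the assay: the limit of > 100000 nM in this assay, at which 1 of the 3 values shown sits.

Open, going by these compounds, is whether activity at this carbon needs a halogen at all, or whether a methyl or methoxy group would serve equally. Chloro would show where between fluoro and bromo the change sets in.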